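This account rests on a few compounds, and the source may have more. Where it says the series, first, only, none or still open, it means among the compounds named here.

Measured compounds:
Compound 1 `C=CCNC(=O)n1c(-c2ccc(OC)cc2)cc(=O)c2c(OC)cc(OC)cc21`: in a functional assay on KOPN-8 cells (Homo sapiens) for antiproliferative activity, with a stated time of 72 h (on this read-out higher numbers stand for an effect only at larger amounts of compound and lower numbers for an effect already at smaller amounts), compound 1 gives 12000 nM.
Compound 2 `COc1ccc(-c2cc(=O)c3c(OC)cc(OC)cc3n2S(=O)(=O)c2ccc(C=O)cc2)cc1`: in this assay compound 2 gives > 34400 nM, which is a limit of this assay and not a number.

Compound 2 thus stands at the weak end of what has been measured: its value sits at the limit of > 34400 nM in this assay, at which 1 of the 2 values shown sits, so only a lower bound on its concentration is known. Going by the values given here, the single measured step, an at least 2.8-fold higher number from compound 1 to compound 2 (0.45 log units; beyond the scatter), concerns a different part of the molecule, namely the exchange of an allylcarbamoyl for a (4-formylphenyl)sulfonyl on the aromatic nitrogen, and it went beyond the scatter toward weaker activity.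

Compound 3 `COc1ccc(-c2cc(=O)c3c(OC)cc(OC)cc3n2S(=O)(=O)c2cc(F)c(F)c(F)c2)cc1` differs from compound 2 by 3,4,5-trifluorophenyl in place of 4-formylphenyl on a sulfonyl sulfur. Among the compounds with values here, no measured step touches this change, and compound 2 itself offers no exact number to build on, so the expectation for compound 3 rests on compound 2 alone. Compound 3 is expected to give about 40000 nM in this assay, within a range from 10000 nM to 150000 nM, and most likely again reported only as a limit. The estimated step is a step that the limit leaves unreadable from compound 2 to compound 3, meaning no change beyond the scatter is expected.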

Compound 3, half-maximal effective concentration: > 65500 nM
Compound 3: only a limit was reported; the forecaster's own chance of this, stated with the estimate: 70%; middle value at least 1.6-fold (0.21 log units) from the limit.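

Compound 2 and compound 3 are both reported only as limits of this assay, not as numbers, and no step can be read for the exchange of 4-formylphenyl for 3,4,5-trifluorophenyl on the sulfonyl sulfur. The compounds shown leave open what exact concentration either compound needs, and whether this exchange changes the antiproliferative effect at all.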